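This account rests on a few compounds, and the source may have more. Where it says the series, first, only, none or still open, it means among the compounds named here.

Compound 1 `Cc1cccc(N2C(=O)CSC2c2cccc(C(=O)NCCCCc3ccccc3)c2)c1`: 10000 nM
Compound 2 `O=C(NCCCCn1cccn1)c1cccc(C2SCC(=O)N2c2ccccn2)c1`: 50000 nM

In a physicochemical assay for solubility, read by turbidimetry, measured as kinetic solubility, at pH 7.4 (a higher number here means a more soluble compound, a lower number a less soluble compound), compound 2 stands highest of the two, with 50000 nM, clearly beyond the scatter from compound 1. Compound 3 `O=C(NCCCCc1ccccc1)c1cccc(C2SCC(=O)N2c2ccccn2)c1` has phenyl in place of 1H-pyrazol-1-yl on a saturated chain carbon, four bonds along the chain from an amide-type nitrogen. Going by the values given here, no measured pair isolates this change. Compound 3 shares the 3-phenylpropyl group with compound 1, which gives 10000 nM, so a fall in this assay beyond the scatter is expected. The expected change is a 2.5-fold lower number from compound 2 to compound 3 (0.40 log units; beyond the scatter). For compound 3 the estimated value is 20000 nM, within a range of 8000 nM to 50000 nM.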

Compound 3, solubility: 20000 nM
For compound 3 middle estimate and measured number coincide at the digits printed; measured number inside the range.
By their numbers in this assay, from the lowest: compounds 1 and 3 (each within the scatter of the next); then compound 2.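

In this assay, phenyl in place of 1H-pyrazol-1-yl on a saturated chain carbon, four bonds along the chain from an amide-type nitrogen, now stands alone as a single change, giving a 2.5-fold lower number from compound 2 to compound 3 (0.40 log units; beyond the scatter). With 3-phenylpropyl held constant, pyridin-2-yl in place of 3-methylphenyl on an amide-type nitrogen in a ring gives a 2.0-fold higher number from compound 1 to compound 3 (0.30 log units; within the scatter), so this pair does not separate those two groups. Nothing measured here explains either step. Going by these compounds, what an amine or a carboxylic acid at the chain end would give in this assay stays open. So does whether the phenyl step holds with 3-methylphenyl in place of pyridin-2-yl.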